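The source may hold more compounds than are shown below. What is called first, only, known or untested is meant among the compounds shown, and "the series" means these compounds.

In a functional assay (Cavia porcellus) with sulfonylurea receptors; K-ATP channels (Homo sapiens) as the target (a higher number here means a weaker inhibitor, a lower number a stronger inhibitor), compound 1 `COc1ccccc1S(=O)(=O)c1ccc(NC(=O)C(C)(O)C(F)(F)F)cc1` gives 1600 nM. Compound 2 `CC(O)(C(=O)Nc1ccc(C(O)c2ccccc2)cc1)C(F)(F)F` is reported in this assay only as a limit, > 30000 nM, and not as a number, the situation recorded as the limit of > 30000 nM in this assay, at which 1 of the 2 values shown sits. Compound 3 `CC(O)(C(=O)Nc1ccc(S(=O)(=O)c2cncs2)cc1)C(F)(F)F` has not yet been measured. It differs from compound 2 by (1,3-thiazol-5-yl)sulfonyl in place of hydroxy(phenyl)methyl on an aromatic carbon — (1,3-thiazol-5-yl)sulfonyl in place of hydroxy(phenyl)methyl on an aromatic carbon, para to a large group. Among the compounds with values here, no measured step between two compounds differing in one place is available, so the expectation rests on the two values shown: compound 1, whose structure stands above, reaches a measurable value, while compound 2 does not. Compound 3 is therefore expected to move toward stronger inhibition by a margin well beyond the scatter. The expected step is an at least 10-fold lower number from compound 2 to compound 3 (1.00 log units; beyond the scatter). Compound 3 is estimated at 3000 nM, between 800 nM and 15000 nM.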

Compound 3, half-maximal inhibitory concentration: 7700 nM
Compound 3: the middle estimate sits 2.6-fold (0.41 log units) below what was measured, and the stated range covers the measured number.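

In this assay, placing (1,3-thiazol-5-yl)sulfonyl on this aromatic carbon, para to a large group, in place of hydroxy(phenyl)methyl gives an at least 3.8-fold lower number from compound 2 to compound 3 (0.59 log units; beyond the scatter). With the sulfonyl kept, the group on the sulfonyl sulfur also matters: 1,3-thiazol-5-yl in place of 2-methoxyphenyl gives a 4.8-fold higher number from compound 1 to compound 3 (0.68 log units; beyond the scatter). The first of these steps has only a lower bound, as compound 2 is reported only as a limit: the limit of > 30000 nM in this assay, at which 1 of the 3 values shown sits.

The change from compound 2 to compound 3 replaces the link and the ring together, so the compounds shown do not divide the gain between the sulfonyl and the 1,3-thiazol-5-yl ring. Also open, on these data alone, is how a sulfonyl sulfur carrying an unsubstituted phenyl, or a phenyl bearing an amine or a carboxylic acid, would compare.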